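The source may hold more compounds than are shown below. What is called first, only, known or untested is meant among the compounds shown, and "the series" means these compounds.

Measured so far in a functional assay on HeLa cells (Homo sapiens) for antiproliferative activity, read by MTT assay, with a stated time of 48 h; a higher number here means a weaker inhibitor, a lower number a stronger inhibitor:
Compound 1 `COc1cc(C(=O)/C=C/c2c[nH]c3ccccc23)cc([N+](=O)[O-])c1OC` gives 1350 nM
Compound 2 `COc1cc(C(=O)/C=C/c2cn(C)c3ccccc23)cc(N)c1OC` gives 668 nM

Compound 2 holds the lower of the two numbers, and its gap to compound 1 lies beyond the usual scatter. Compound 3 `COc1cc(C(=O)/C=C/c2cn(C)c3ccccc23)cc([N+](=O)[O-])c1OC` has not yet been measured. It differs from compound 2 by nitro in place of amino on an aromatic carbon. Within the data shown here, no measured pair isolates this exchange, so the expectation rests on thin evidence. Compound 1 also carries the nitro group and gives 1350 nM while differing from compound 3 elsewhere too. A small step toward a higher number in this assay is therefore expected, not clearly beyond the scatter. The estimate means a 1.5-fold higher number from compound 2 to compound 3 (0.18 log units; within the scatter) as the expected step. Compound 3 is estimated at 1000 nM (expected range 300 nM to 3000 nM).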

Compound 3, half-maximal inhibitory concentration: 1960 nM
The estimate for compound 3 lay 2.0-fold (0.29 log units) below the measured number, within the range that was stated.
By their numbers in this assay, from the lowest: compound 2; then compounds 1 and 3 (each within the scatter of the next).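

In this assay, the aromatic carbon ortho to a methoxy group now has a single-place comparison: nitro in place of amino gives a 2.9-fold higher number from compound 2 to compound 3 (0.47 log units; beyond the scatter). The earlier pair, compound 1 and compound 2, differed in two places and could not isolate this exchange. With nitro held fixed, methyl in place of hydrogen on an aromatic nitrogen gives a 1.5-fold higher number from compound 1 to compound 3 (0.16 log units; within the scatter), so that exchange does not separate these two compounds in this assay.

Nothing measured here explains why the amino and nitro compounds differ. Still open, going by these compounds, is whether the amino and nitro exchange gives a similar step with hydrogen on the aromatic nitrogen, and how a hydroxyl group or an acetamide on this same aromatic carbon would compare with amino and nitro.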